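Swapping an Ester Tail for an Amine Tail

This account rests on a few compounds, and the source may have more. Where it says the series, first, only, none or still open, it means among the compounds named here.

Three compounds share one core and were tested in a functional assay on HeLa cells (Homo sapiens) for cytotoxicity, read by neutral red uptake, with a stated time of 3 days; a higher number here means a weaker inhibitor, a lower number a stronger inhibitor. Compound 1 `Nc1ccc(-c2cc(=O)c3c(N)c(F)c(Cl)c(F)c3o2)cc1F` reaches only the limit of this assay, giving > 100000 nM. Compound 2 `CCC(=O)OCc1c(F)c(N)c2c(=O)cc(-c3ccc(N)c(F)c3)oc2c1F` gives 69000 nM, and compound 3 `CCCCCC(=O)OCc1c(F)c(N)c2c(=O)cc(-c3ccc(N)c(F)c3)oc2c1F` gives 34000 nM, which is the lowest of the two real numbers here; the step of a 2.0-fold lower number from compound 2 to compound 3 (0.31 log units; beyond the scatter) sets it apart from compound 2, and the step of an at least 2.9-fold lower number from compound 1 to compound 3 (0.46 log units; beyond the scatter) sets it apart from compound 1.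

Compound 4 `CN(C)CCCOCc1c(F)c(N)c2c(=O)cc(-c3ccc(N)c(F)c3)oc2c1F` is not yet measured. It differs from compound 3 by 3-(dimethylamino)propyl in place of pentylcarbonyl on an oxygen on a saturated carbon: an ester tail becomes an ether tail carrying a tertiary amine. No measured step changes the tail in this way; the only guidance is that adding a tail of this kind in an at least 2.9-fold lower number from compound 1 to compound 3 (0.46 log units; beyond the scatter) and lengthening it in a 2.0-fold lower number from compound 2 to compound 3 (0.31 log units; beyond the scatter) each lowered the number modestly. Within the data shown here, with no directly comparable step, the expected change is none beyond the scatter, so for compound 4 the estimated step is a 1.1-fold lower number from compound 3 to compound 4 (0.05 log units; within the scatter), and compound 4 is expected to give about 30000 nM, within a range from 8000 nM to 100000 nM.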

Compound 4, half-maximal inhibitory concentration: 12000 nM
Compound 4: the middle estimate sits 2.5-fold (0.40 log units) above what was measured; the range from low to high includes it.
By their numbers in this assay, from the lowest: compound 4; then compound 3; then compound 2. At a limit, above all of these: compound 1.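

Up to this point, every tail on this saturated carbon was an ester, so compound 4 is the first evidence that the ester carbonyl is not needed for activity: in this assay, the ether tail ending in a tertiary amine gives a 2.8-fold lower number from compound 3 to compound 4 (0.45 log units; beyond the scatter). The gap to the shorter ester is wider, at a 5.8-fold lower number from compound 2 to compound 4 (0.76 log units; beyond the scatter), and 3-(dimethylamino)propyl has fewer heavy atoms than the pentylcarbonyl it replaces, so tail length alone no longer describes the trend. The last step, an at least 8.3-fold lower number from compound 1 to compound 4 (0.92 log units; beyond the scatter), is only a floor: the limit of > 100000 nM in this assay, at which 1 of the 4 values shown sits.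

The compounds shown leave open whether the ether oxygen or the amine goes with the lower number. A plain pentyl ether and a dimethylamino chain of another length would help separate the two.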